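A few compounds are considered here, and "the series" means these few. Any claim that something is new, unique, unknown or untested is made for them only; others in the source may bear on it.

Measured compounds:
Compound 1 `CCN1CCN(c2cc(C)c3cc(NC(=O)CSc4ccncc4)ccc3n2)CC1`: 8200 nM
Compound 2 `COc1ccc(CCC(=O)Nc2ccc3nc(N4CCN(C)CC4)cc(C)c3c2)cc1`: 250 nM

In an assay on CHO cells for inhibition of melanin-concentrating hormone receptor 1 (Homo sapiens) (on this read-out lower numbers stand for stronger inhibition and higher numbers for weaker inhibition), compound 1 gives 8200 nM, the highest of the two numbers recorded. Among the compounds with values here, the only other measured compound, compound 2, gives 250 nM in this assay, a markedly lower number whose gap to compound 1 lies beyond the usual scatter. Within the data shown here, compound 2 differs from compound 1 in more than one place, so these two values show only that the shared core can reach a far lower number with a different side chain on the amide.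

Compound 3 `CCN1CCN(c2cc(C)c3cc(NC(=O)COc4cccc(C)c4)ccc3n2)CC1` has not yet been measured. It differs from compound 1 by 3-methylphenoxy in place of (pyridin-4-yl)sulfanyl on a saturated chain carbon bound to a carbonyl carbon. Among the measured compounds shown here, no step between measured compounds isolates this change, so its size can only be estimated from the two values shown. The shift toward an aryl ether side chain is expected to move the number downward, by a step of about a 5.5-fold lower number from compound 1 to compound 3 (0.74 log units; beyond the scatter), given that compound 2 reaches 250 nM with a carbon-only aromatic side chain. Compound 3 is therefore estimated at 1500 nM, within a range from 300 nM to 7000 nM.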

Compound 3, half-maximal inhibitory concentration: 6600 nM
The estimate for compound 3 lay 4.4-fold (0.64 log units) below the measured number, and the stated range covers the measured number.
By their numbers in this assay, from the lowest: compound 2; then compounds 3 and 1 (each within the scatter of the next).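

In this assay, within the data shown here, 3-methylphenoxy in place of (pyridin-4-yl)sulfanyl on a saturated chain carbon bound to a carbonyl carbon gives a 1.2-fold lower number from compound 1 to compound 3 (0.09 log units; within the scatter), the first comparison here of compounds that differ in one place. At this position, a six-membered aromatic ring of carbon only bound through oxygen therefore cannot be told apart from a six-membered aromatic ring with 1 hetero atom bound through sulfur, though the ring, the linking atom and the methyl all change at once, so separate effects of these parts could offset one another. Nothing available explains why the two side chains give values within the scatter of each other.

The linking atom and the ring changed together, so the compounds shown leave open whether pyridin-4-yloxy or phenylsulfanyl, each of which keeps one part of compound 1 and takes one part of compound 3, would also stay within the scatter. Also open, as far as these compounds go, is whether a longer chain ending in a methoxyphenyl group at this place, with the rest of compound 1 unchanged, would give a number beyond the scatter from compound 1.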